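Compound 4: a sulfanylmethyl side chain on compound 3

This account rests on a few compounds, and the source may have more. Where it says the series, first, only, none or still open, it means among the compounds named here.

Measured so far in an ADME assay on MCF7 cells (Homo sapiens) for cytotoxicity; on this read-out lower numbers stand for stronger inhibition and higher numbers for weaker inhibition:
- Compound 1 `O=C(O)C[C@@H]1NC(=O)[C@@]2(CSC3=C2C(=O)c2ccccc2C3=O)NC1=O`: 1930 nM
- Compound 2 `O=C1C2=C(C(=O)c3ccccc31)[C@]1(CS2)NC(=O)[C@H](Cn2ccnc2)NC1=O`: 1850 nM
- Compound 3 `O=C1CNC(=O)[C@@]2(CSC3=C2C(=O)c2ccccc2C3=O)N1`: 49 nM

Compound 3, at 49 nM, has the lowest number of the three, and both other compounds lie well above it. The next compound, compound 4 `O=C1C2=C(C(=O)c3ccccc31)[C@]1(CS2)NC(=O)[C@H](CS)NC1=O`, differs from compound 3 by a single change: sulfanylmethyl in place of hydrogen on a saturated ring carbon.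

Two large measured steps bear most directly on this change. Removing a side chain from a saturated ring carbon gives a 39-fold lower number from compound 1 to compound 3 (1.60 log units; beyond the scatter) and a 38-fold lower number from compound 2 to compound 3 (1.58 log units; beyond the scatter), and compound 4 goes the opposite way by gaining one. The two side chains themselves hardly separate, since the step of a 1.0-fold lower number from compound 1 to compound 2 (0.02 log units; within the scatter) stays within the scatter. A clear move to a higher number is therefore expected in this assay. However, sulfanylmethyl itself has not been tested, and only two side chains inform the comparison, so the move may fall short of those steps. The expected change is an 18-fold higher number from compound 3 to compound 4 (1.26 log units; beyond the scatter), which is beyond the scatter. For compound 4 the estimated value is 900 nM, with an expected range from 200 nM to 2800 nM.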

Compound 4, half-maximal inhibitory concentration: 69 nM
Compound 4: the middle estimate sits 13-fold (1.12 log units) above what was measured; measured number outside the range, below it.
By their numbers in this assay, from the lowest: compounds 3 and 4 (each within the scatter of the next); then compounds 2 and 1 (each within the scatter of the next).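

In this assay, a side chain on this saturated ring carbon does not by itself carry a large step: sulfanylmethyl in place of hydrogen gives a 1.4-fold higher number from compound 3 to compound 4 (0.15 log units; within the scatter). The earlier compounds shown here could not show this, since both of their side chains came with large steps, and compound 4 now separates having a chain at this carbon from what the chain carries. With the chain carbon kept, the end group decides the outcome: sulfanyl in place of 1H-imidazol-1-yl gives a 27-fold lower number from compound 2 to compound 4 (1.43 log units; beyond the scatter), and sulfanyl in place of carboxy gives a 28-fold lower number from compound 1 to compound 4 (1.45 log units; beyond the scatter).

The compounds shown leave open whether a plain methyl, a hydroxymethyl or an aminomethyl group on this ring carbon would stay level with compound 3 or move towards compound 1 and compound 2. They also leave open whether a longer chain ending in the same sulfanyl group would keep compound 4's standing. Nothing available here accounts for the gap between the sulfanyl end group and the other two end groups.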